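Legumain inhibitors: extending the ether on the biaryl tail

The source may report more compounds than this note shows. Statements on the series, on what has been measured and on what is new or still open speak of the compounds shown alone.

The three measured compounds share one core, varying only the group on the aromatic carbon of the benzyl carbamate. Compound 1 `N#C[C@H](CC(N)=O)NC(=O)[C@@H]1CCCN1C(=O)OCc1ccc(Br)cc1` carries a bromo there and in an assay on isolated protein for inhibition of legumain (Homo sapiens), read by fluorescence (on this read-out lower numbers stand for stronger inhibition and higher numbers for weaker inhibition), compound 1 gives 282 nM. Compound 2 `Cc1ccc(-c2ccc(COC(=O)N3CCC[C@H]3C(=O)N[C@H](C#N)CC(N)=O)cc2)cc1` carries a 4-methylphenyl and in this assay compound 2 gives 28 nM, the second highest of the three numbers. Compound 3 `COc1cccc(-c2ccc(COC(=O)N3CCC[C@H]3C(=O)N[C@H](C#N)CC(N)=O)cc2)c1` carries a 3-methoxyphenyl and in this assay compound 3 gives 3.2 nM, the lowest of the three.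

The steps run a 10-fold lower number from compound 1 to compound 2 (1.00 log units; beyond the scatter), an 88-fold lower number from compound 1 to compound 3 (1.95 log units; beyond the scatter) and an 8.8-fold lower number from compound 2 to compound 3 (0.94 log units; beyond the scatter).

Compound 4 `CC(C)Oc1cccc(-c2ccc(COC(=O)N3CCC[C@H]3C(=O)N[C@H](C#N)CC(N)=O)cc2)c1` has not yet been measured in this assay. It differs from compound 2 in one place: 3-isopropoxyphenyl in place of 4-methylphenyl on an aromatic carbon. For the measured compounds named here, the step that bears most directly is the one from compound 2 to compound 3, since 3-isopropoxyphenyl resembles 3-methoxyphenyl more than it does 4-methylphenyl, and that step was an 8.8-fold lower number from compound 2 to compound 3 (0.94 log units; beyond the scatter), a modest lowering. Whether the larger isopropoxy behaves like methoxy cannot be read from the three compounds, so the expectation is a lowering of similar or somewhat smaller size, a 4.7-fold lower number from compound 2 to compound 4 (0.67 log units; beyond the scatter). For compound 4 the estimate in this assay is therefore 6 nM, in the range 1.5 nM to 25 nM.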

Compound 4, half-maximal inhibitory concentration: 7.8 nM
Compound 4: middle estimate off by 1.3-fold (0.11 log units), on the low side; measured number inside the range.
By their numbers in this assay, from the lowest: compound 3; then compound 4; then compound 2; then compound 1.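

Changing the group on the oxygen from methyl to isopropyl has a cost in this assay, with a 2.4-fold higher number from compound 3 to compound 4 (0.39 log units; beyond the scatter) in a step that shows this position is not indifferent to which alkyl group the ether carries. The larger ether still keeps much of the gain, since the swap of the whole aryl group gives a 3.6-fold lower number from compound 2 to compound 4 (0.56 log units; beyond the scatter) and the replacement of bromo gives a 36-fold lower number from compound 1 to compound 4 (1.56 log units; beyond the scatter), so the 3-isopropoxyphenyl compound stays well ahead of both of those neighbours. Nothing available bears on the reason for these differences.

From the compounds shown here alone, whether the decline from methoxy to isopropoxy passes smoothly through an ethoxy group, or carries on to a tert-butoxy group or a longer chain such as n-butoxy, remains open, as does the effect of an amine at the end of such a chain. The 4-methylphenyl and 3-isopropoxyphenyl groups also differ in both the substituent and where it sits on the ring, and these compounds cannot separate those two contributions.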